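A Further Chloro Group on the Arylidene Ring

This account rests on a few compounds, and the source may have more. Where it says the series, first, only, none or still open, it means among the compounds named here.

Of the compounds shown here, three sharing one core have so far been tested in a functional assay on L132 cells (Homo sapiens) for cytotoxicity, read by MTT assay, with a stated time of 72 h; a higher number here means that more compound is needed for the effect, a lower number that less compound is needed. Compound 1 `O=C1/C(=C\c2ccc(O)cc2)c2ccccc2N1c1c(Cl)cccc1Cl` gives 30 ug/mL. Compound 3 `O=C1/C(=C\c2ccc(Cl)cc2)c2ccccc2N1c1c(Cl)cccc1Cl` gives 9 ug/mL, the lowest of the two numbers, and the step of a 3.3-fold lower number from compound 1 to compound 3 (0.52 log units; beyond the scatter) lies beyond the scatter. Compound 2 `O=C1/C(=C\c2ccccc2Cl)c2ccccc2N1c1c(Cl)cccc1Cl` reaches only the assay limit, > 100 ug/mL, so no number exists for it (the limit of > 100 ug/mL in this assay, at which 1 of the 3 values shown sits). The moves between the chloro-bearing pair are the ones that matter here: an at least 11-fold lower number from compound 2 to compound 3 (1.04 log units; beyond the scatter) and, from the hydroxy compound, an at least 3.3-fold higher number from compound 1 to compound 2 (0.52 log units; beyond the scatter).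

Compound 4 `O=C1/C(=C\c2c(Cl)cccc2Cl)c2ccccc2N1c1c(Cl)cccc1Cl` has not yet been measured in this assay. It differs from compound 3 in one place: 2,6-dichlorophenyl in place of 4-chlorophenyl on a double-bonded chain carbon bound to a double-bonded ring carbon. The change keeps a chloro on the phenyl ring but adds a second one, giving a 2,6-dichlorophenyl pattern that recalls the 2-chlorophenyl of compound 2, for which only a limit was recorded. On that basis a higher number than compound 3 is expected, and the step is estimated at a 5.0-fold higher number from compound 3 to compound 4 (0.70 log units; beyond the scatter), probably a large one, with a fair chance that compound 4 also reports only a limit. Compound 4 is therefore expected to give about 45 ug/mL, within a range from 12 ug/mL to 100 ug/mL.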

Compound 4, concentration for half-maximal effect: > 100 ug/mL
Compound 4: a limit, no number (the forecaster's own chance of this, stated with the estimate: 35%); middle value at least 2.2-fold (0.34 log units) from the limit.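

Among the chloro-bearing groups on a double-bonded chain carbon bound to a double-bonded ring carbon, only the 4-chlorophenyl of compound 3 gives a readable number in this assay, whereas the 2-chlorophenyl of compound 2 and the 2,6-dichlorophenyl of compound 4 both end at a limit and not at a number: the limit of > 100 ug/mL in this assay, at which 2 of the 4 values shown sit.

Exchanging 4-chlorophenyl for 2,6-dichlorophenyl gives an at least 11-fold higher number from compound 3 to compound 4 (1.04 log units; beyond the scatter), and exchanging 4-hydroxyphenyl for the same group gives an at least 3.3-fold higher number from compound 1 to compound 4 (0.52 log units; beyond the scatter). Going by these compounds, both compound 2 and compound 4 are reported as limits, so the step between them cannot be read, and what the second chloro adds to the 2-chlorophenyl of compound 2 remains unknown.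

The compounds shown leave open whether a readable number at this place depends on chloro itself, or whether a methoxy group, an amine or a carboxylic acid on the phenyl ring in place of the chloro of compound 3 would also give one. They also leave open how far compound 2 and compound 4 lie beyond the limit, and whether these two differ from each other at all.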